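An open-chain group replaces a five-membered heteroaromatic ring

The source may report more compounds than this note shows. Statements on the series, on what has been measured and on what is new or still open speak of the compounds shown alone.

Compound 1: `c1ccc(-c2cnoc2)c(NCC2=NCCN2)c1`; in a functional assay for activation of Alpha-1D adrenergic receptor (Homo sapiens) (a higher number here means that more compound is needed for the effect, a lower number that less compound is needed), compound 1 gives < 100000 nM
Compound 2: `Cc1nc(-c2ccccc2NCC2=NCCN2)no1`; in this assay compound 2 gives < 5020 nM

Both values are limits of this assay and not numbers. For compound 1 the result is a limit, < 100000 nM. For compound 2 the result is likewise a limit, < 5020 nM. Among the compounds with values here, the one measured step, a step that the two limits leave unreadable from compound 1 to compound 2, cannot be sized because the limit of < 100000 nM in this assay, at which 1 of the 2 values shown sits, and the limit of < 5020 nM in this assay, at which 1 of the 2 values shown sits, bound each value from one side only. Compound 2 therefore stands at its limit and nowhere more precisely.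

Compound 3 `CO/N=C/c1ccccc1NCC1=NCCN1` differs from compound 2 by a group of 4 heavy atoms (2 carbon, 1 nitrogen, 1 oxygen; no ring) in place of a group of 6 heavy atoms (3 carbon, 2 nitrogen, 1 oxygen; one five-membered aromatic ring with 3 hetero atoms), on an aromatic carbon. Within the data shown here, no measured step bears on this exchange, and the single measured step offers no readable size; the expectation can rest only on compound 2 sitting at its limit < 5020 nM. Compound 3 is expected to give 2500 nM, estimated between 400 nM and 15000 nM. The estimated step that the limit leaves unreadable from compound 2 to compound 3 is thus expected to stay near the scatter, in no firm direction.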

Compound 3, half-maximal effective concentration: < 5020 nM
Compound 3: a limit, no number (the forecaster's own chance of this, stated with the estimate: 40%); the middle value is on the limit's open side.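

In this assay compound 3 gives < 5020 nM, which is a limit and not a number. Within the data shown here, no step among compound 1, compound 2 and compound 3 can be read. The compounds shown leave open how the open-chain group and the two five-membered aromatic rings compare.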